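The source may hold more compounds than are shown below. What is called first, only, known or untested is meant among the compounds shown, and "the series" means these compounds.

Compound 1 `Cc1cc(/C=C/C#N)cc(C)c1Oc1ccc([N+](=O)[O-])c(Nc2ccc(C#N)cc2)n1` and compound 3 `Cc1cc(/C=C/C#N)cc(C)c1Oc1ccc(N)c(Nc2ccc(C#N)cc2)n1` share one core, while compound 2 `CC(=O)/C=C/c1cc(C)c(Oc2cc(Nc3ccc(C#N)cc3)c([N+](=O)[O-])cc2[N+](=O)[O-])c(C)c1` and compound 4 `CC(=O)/C=C/c1cc(C)c(Oc2cc(Nc3ccc(C#N)cc3)c(N)cc2[N+](=O)[O-])c(C)c1` share another; how the two cores differ is not broken down here. In an ADME assay on TZM cells (Homo sapiens) for cytotoxicity, read by XTT assay, with a stated time of 4 days (on this read-out higher numbers stand for lower toxicity in this test and lower numbers for higher toxicity in this test), compound 1 gives only a limit of the test, > 48600 nM. In this assay compound 3 gives 9750 nM and compound 2 gives 24400 nM. The change from compound 1 to compound 3 is amino in place of nitro on an aromatic carbon, and it brought an at least 4.9-fold lower number from compound 1 to compound 3 (0.69 log units; beyond the scatter), a step that rests on (the limit of > 48600 nM in this assay, at which 1 of the 3 values shown sits). The change from compound 2 to compound 4 is amino in place of nitro on an aromatic carbon, the same kind of change, though here the ring is of carbon only and the site is meta to a nitro group rather than two atoms from the ring nitrogen. Because compound 3 gave 9750 nM after this kind of change, compound 4 is expected to show a 3.1-fold lower number from compound 2 to compound 4 (0.48 log units; beyond the scatter). Compound 4 is estimated at 8000 nM, likely between 3000 nM and 20000 nM.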

Compound 4, half-maximal cytotoxic concentration: 5880 nM
Estimate against measurement, compound 4: 1.4-fold (0.13 log units) above, and the stated range covers the measured number.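

In this assay, amino in place of nitro on an aromatic carbon brought a 4.1-fold lower number from compound 2 to compound 4 (0.62 log units; beyond the scatter), so the number fell on both cores shown: the same change on two cores in this assay, an at least 4.9-fold lower number (0.69 log units; beyond the scatter) from compound 1 to compound 3 and a 4.1-fold lower number (0.62 log units; beyond the scatter) from compound 2 to compound 4; the limit leaves it open whether they differ. Compound 1 gives a limit of the test and not a number: the limit of > 48600 nM in this assay, at which 1 of the 4 values shown sits. Going by these compounds, the direction of the change therefore carried over between these two cores, but whether its size is the same on both remains unknown, and two cores say nothing firm about any other core.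

The compounds shown leave open how other groups on that aromatic carbon, such as a hydroxyl or a methylamino group, would compare with amino and nitro. They also leave open whether a carboxylic acid there would follow the same direction.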